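Benzyloxy added to compound 2

The source may report more compounds than this note shows. Statements on the series, on what has been measured and on what is new or still open speak of the compounds shown alone.

Among the compounds with values here, compound 2 (`COc1ccc(-c2sccc2-c2cc(OC)c(OC)c(OC)c2)cc1`) gives 8880 nM in a functional assay on KB cells (Homo sapiens) for antiproliferative activity, read by MTT assay, with a stated time of 72 h (a higher number here means a weaker inhibitor, a lower number a stronger inhibitor), the only number so far. Compound 1 (`CCOC(=O)c1cc(-c2cc(OC)c(OC)c(OC)c2)c(-c2ccc(OC)c(OCc3ccccc3)c2)s1`), which also carries benzyloxy, reads > 100000 nM, a limit. Compound 3 (`COc1cc(-c2ccsc2-c2cccc(Br)c2)cc(OC)c1OC`) reads > 100000 nM, also a limit. Compound 4 (`COc1ccc(-c2sccc2-c2cc(OC)c(OC)c(OC)c2)cc1OCc1ccccc1`) departs from compound 2 by benzyloxy in place of hydrogen on an aromatic carbon, with benzyloxy in place of hydrogen on an aromatic carbon, ortho to a methoxy group. Within the data shown here, the one measured step, an at least 11-fold higher number from compound 2 to compound 3 (1.05 log units; beyond the scatter), is large and alters the same 4-methoxyphenyl group. A weakening beyond the scatter is therefore expected in this assay, estimated as a 3.9-fold higher number from compound 2 to compound 4 (0.60 log units; beyond the scatter). For compound 4 the estimate is 35000 nM, with an expected range of 10000 nM to 100000 nM.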

Compound 4, half-maximal inhibitory concentration: > 100000 nM
Compound 4 ended at the assay's limit (the forecaster's own chance of this, stated with the estimate: 45%); middle value at least 2.8-fold (0.45 log units) away from the limit.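

In this assay, benzyloxy in place of hydrogen, ortho to a methoxy group, gives an at least 11-fold higher number from compound 2 to compound 4 (1.05 log units; beyond the scatter); the earlier step replaced the whole 4-methoxyphenyl group, whereas this one shows that an addition to that group, with the methoxy kept, also loses activity. The step from compound 1 to compound 4 cannot be read, since both values are limits. The value of compound 4 is itself a limit, so the loss has no upper size: the limit of > 100000 nM in this assay, at which 3 of the 4 values shown sit.

Open, from the compounds shown here alone, is whether a hydroxyl or a fluorine at this position would keep the activity of compound 2. Also open, going by these compounds, is whether any group here would improve on compound 2.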